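Glucagon Receptor Antagonists: From Tetrazole-Type Chain to Carboxy

A few compounds are considered here, and "the series" means these few. Any claim that something is new, unique, unknown or untested is made for them only; others in the source may bear on it.

Three analogues built on a shared core have been measured in a functional assay on CHO cells for antagonist activity at Glucagon receptor (Homo sapiens), read by cAMP accumulation, with stated times of 30 min and 45 min; on this read-out higher numbers stand for weaker inhibition and lower numbers for stronger inhibition. Compound 1 `C[C@H](c1ccc(C(=O)NCCC(=O)O)cc1)N1C(=O)C(c2ccccc2F)=N[C@]12CC[C@@H](C(C)(C)C)CC2` gives 350 nM. Compound 3 `CC(C)(C)CC[C@H](c1ccc(C(=O)NCc2nn[nH]n2)cc1)N1C(=O)C(c2ccc(C(F)(F)F)cc2)=N[C@]12CC[C@@H](C(C)(C)C)CC2` gives 160 nM. Compound 2 `CC(C)(C)CC[C@H](c1ccc(C(=O)NCCC2=NNNN2)cc1)N1C(=O)C(c2cc(Cl)cc(Cl)c2)=N[C@]12CC[C@@H](C(C)(C)C)CC2` gives 890 nM, the highest of the three numbers; its nearest neighbour is compound 1 and its most distant is compound 3, both gaps lying beyond the scatter.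

The step under study leads from compound 2 to the unmeasured compound 4 `CC(C)(C)CC[C@H](c1ccc(C(=O)NCC(=O)O)cc1)N1C(=O)C(c2cc(Cl)cc(Cl)c2)=N[C@]12CC[C@@H](C(C)(C)C)CC2`. The change is a group of 3 heavy atoms (1 carbon, 2 oxygen; no ring) in place of a group of 6 heavy atoms (2 carbon, 4 nitrogen; one five-membered non-aromatic ring with 4 hetero atoms), on a saturated chain carbon bound to an amide-type nitrogen. Among the measured compounds shown here, no measured pair differs in exactly this way, so the size of the step can only be anticipated.

Compound 1 carries a carboxy-terminated chain and stands at a lower number than compound 2, while compound 3 stands lower still. On that basis the author expects compound 4 to move downward from compound 2 by a modest step, a 1.8-fold lower number from compound 2 to compound 4 (0.25 log units; within the scatter), and estimates its value in this assay at 500 nM, within a range from 200 nM to 1500 nM.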

Compound 4, half-maximal inhibitory concentration: 2700 nM
For compound 4 the middle estimate is 5.4-fold (0.73 log units) below the measured one; the measured number lies above the stated range.
By their numbers in this assay, from the lowest: compound 3; then compound 1; then compound 2; then compound 4.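

In this assay, putting carboxy in place of the five-membered non-aromatic ring with 4 hetero atoms, on a saturated chain carbon bound to an amide-type nitrogen, gives a 3.0-fold higher number from compound 2 to compound 4 (0.48 log units; beyond the scatter). Among the compounds shown here, this is the only pair in the set that differs in one place, so it is the first direct reading of this position: here, the carboxy group raises the number rather than lowering it. Nothing in the data accounts for this rise.

Going by these compounds, what a methyl ester or a primary amide would do at the same place remains open, as does the effect of a longer chain ending in carboxy on the rest of compound 4. Whether the step would keep its direction and size with other groups on the shared core is also unresolved.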